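Nitroimidazooxazines with aryl pyrazoles in a Vero cytotoxicity assay

A few compounds are considered here, and "the series" means these few. Any claim that something is new, unique, unknown or untested is made for them only; others in the source may bear on it.

Compound 1 `O=[N+]([O-])c1cn2c(n1)OC[C@@H](OCc1cnn(-c3ccc(C(F)(F)F)cc3)c1)C2` and compound 2 `O=[N+]([O-])c1cn2c(n1)OC[C@@H](OCc1cnn(-c3ccc(F)cc3)c1)C2` share one core and differ by fluoro in place of trifluoromethyl on an aromatic carbon. In an ADME assay on Vero cells (Chlorocebus sabaeus) for cytotoxicity, with a stated time of 72 h (on this read-out higher numbers stand for weaker inhibition and lower numbers for stronger inhibition), compound 1 gives only a limit, > 128000 nM. In this assay compound 2 likewise reaches only a limit, > 128000 nM. The step that the two limits leave unreadable from compound 1 to compound 2 stays unreadable because of the limit of > 128000 nM in this assay, at which 3 of the 3 values shown sit. Compound 3 `O=[N+]([O-])c1cn2c(n1)OC[C@@H](OCc1ccn(-c3ccc(C(F)(F)F)cc3)n1)C2` holds the same atoms as compound 1 joined differently; the difference between the two cores is not broken down here. In this assay compound 3 also gives only a limit, > 128000 nM. Compound 4 `O=[N+]([O-])c1cn2c(n1)OC[C@@H](OCc1ccn(-c3ccc(F)cc3)n1)C2` carries the same change against compound 3: fluoro in place of trifluoromethyl on an aromatic carbon. The step expected here, a step that the limit leaves unreadable from compound 3 to compound 4, rests on three values that all sit at a limit, because of the limit of > 128000 nM in this assay, at which 3 of the 3 values shown sit. Compound 4 is therefore expected to give 150000 nM.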

Compound 4, half-maximal inhibitory concentration: > 128000 nM
Compound 4: no number, only a limit; the forecaster's own chance of this, stated with the estimate: 90%; the middle value is on the limit's open side.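

Compound 4, like compound 3, gives only a limit in this assay, so no step can be read between them: (the limit of > 128000 nM in this assay, at which 4 of the 4 values shown sit). The compounds shown leave open whether fluoro in place of trifluoromethyl changes this read-out at all.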